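Compound 3 to compound 4: a series at its limit

The source may hold more compounds than are shown below. What is called first, only, known or untested is meant among the compounds shown, and "the series" means these compounds.

In a physicochemical assay for solubility, using the shake flask method, measured as kinetic solubility, with a stated time of 2 h, at pH 7.4 (a lower number here means a less soluble compound, a higher number a more soluble compound), compound 1 (`CN(Cc1ccccc1)c1cc(C(=O)Nc2ccccc2)ncn1`) gives < 5000 nM as a limit. Compound 2 (`CN(Cc1ccc(Cl)cc1)c1cc(C(=O)Nc2ccccc2)ncn1`) gives < 5000 nM as a limit. Compound 3 (`CN(Cc1ccccc1Cl)c1cc(C(=O)Nc2ccccc2)ncn1`) gives < 5000 nM as a limit, so its standing carries no number. All three readings sit at one limit (the limit of < 5000 nM in this assay, at which 3 of the 3 values shown sit). Compound 4 (`CN(Cc1ccc(C#N)cc1)c1cc(C(=O)Nc2ccccc2)ncn1`) carries 4-cyanophenyl in place of 2-chlorophenyl on a saturated chain carbon bound to a nitrogen on an aromatic ring. The steps a step that the two limits leave unreadable from compound 1 to compound 2 and a step that the two limits leave unreadable from compound 1 to compound 3 and a step that the two limits leave unreadable from compound 2 to compound 3 bear on this change but give no size to carry over. No step beyond the scatter is therefore expected in this assay and the estimate is a step that the limit leaves unreadable from compound 3 to compound 4 in no firm direction. Compound 4 is expected at 3000 nM within an estimated range of 1000 nM to 8000 nM.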

Compound 4, solubility: < 5000 nM
Compound 4: only a limit was reported; the forecaster's own chance of this, stated with the estimate: 80%; the middle value is on the limit's open side.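

Compound 4 also gives only a limit in this assay, so no step among compound 1, compound 2, compound 3 and compound 4 can be read: the limit of < 5000 nM in this assay, at which 4 of the 4 values shown sit.

Going by these compounds, the true solubility of each compound, and any difference between them, stays open.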